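Triazole thioether series: benzyl in place of 3-methylphenyl

The compounds below may be only part of what the source reports. "The series", "measured", "known", "first", "only" and "open" are said of these compounds alone.

Among the measured compounds shown here, compound 3 `Cc1cccc(-c2nnc(SCCCN3CCN(c4ccccn4)CC3)[nH]2)c1` is the only member with a numerical reading: in a functional assay on HL-60 cells (Homo sapiens) for cytotoxicity, read by MTT assay, with a stated time of 24 h (a higher number here means a weaker inhibitor, a lower number a stronger inhibitor), compound 3 gives 29400 nM. Compound 1 `CCN1CCN(CCCSc2nnc(-c3ccc(C)cc3)[nH]2)CC1` reaches only the assay limit, > 300000 nM. Compound 2 `Cc1cccc(-c2nnc(SCCCN3CCN(c4ccccc4)CC3)[nH]2)c1` likewise stops at a limit, > 300000 nM, and sits there (the limit of > 300000 nM in this assay, at which 2 of the 3 values shown sit). For the measured compounds named here, the single measured step, an at least 10-fold lower number from compound 2 to compound 3 (1.00 log units; beyond the scatter), concerns the amine nitrogen in the ring, not the aromatic carbon. Compound 4 `c1ccc(Cc2nnc(SCCCN3CCN(c4ccccn4)CC3)[nH]2)cc1` differs from compound 3 by benzyl in place of 3-methylphenyl on an aromatic carbon. Going by the values given here, no measured step touches this position, so no guidance on direction exists; a change within the scatter is expected, with a weaker reading as the open risk. Compound 4 is estimated at 40000 nM, range 10000 nM to 200000 nM, an expected step of a 1.4-fold higher number from compound 3 to compound 4 (0.13 log units; within the scatter).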

Compound 4, half-maximal inhibitory concentration: > 300000 nM
Compound 4 was reported as a limit (the forecaster's own chance of this, stated with the estimate: 25%); middle value at least 7.5-fold (0.87 log units) away from the limit.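

At this aromatic carbon, benzyl in place of 3-methylphenyl gives an at least 10-fold higher number from compound 3 to compound 4 (1.00 log units; beyond the scatter) in this assay. The position therefore responds to the change, even though the two groups have the same heavy-atom count and both carry one six-membered aromatic ring. Compound 4 gives only a limit, so this step has no upper bound, and compound 3 remains the only numerical reading: the limit of > 300000 nM in this assay, at which 3 of the 4 values shown sit.

From the compounds shown here alone, it remains open whether 4-methylphenyl at this position, with the pyridin-2-yl kept, retains a numerical reading. Also open, going by these compounds, is how an amine or a carboxylic acid on the aromatic ring of compound 3 reads.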